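A few compounds are considered here, and "the series" means these few. Any claim that something is new, unique, unknown or untested is made for them only; others in the source may bear on it.

Of the compounds shown here, three built on one shared core have so far been measured in an ADME assay on microsomes from liver (Mus musculus) for metabolic stability; a higher number here means that the compound lasts longer, a lower number that the compound disappears faster. Compound 1 `CC(C)C(c1ncc[nH]1)c1ccc(-c2ccc3cccc(F)c3c2)[nH]c1=O` is reported only as a limit in this assay, namely < 0.0667 h. Compound 2 `CC(C)NC(=O)CC(c1ccc(-c2ccc3cccc(F)c3c2)[nH]c1=O)C(C)C` likewise reaches only the limit of < 0.0667 h in this assay. Compound 3 `CC(C)C(c1ccc(-c2ccc3cccc(F)c3c2)[nH]c1=O)N1CCCCS1(=O)=O` does give a number in this assay, 0.0733 h. The step that the two limits leave unreadable from compound 1 to compound 2 stays unreadable, since two of the three values sit at the limit of < 0.0667 h in this assay, at which 2 of the 3 values shown sit. The steps of an at least 1.0-fold higher number from compound 1 to compound 3 (0.04 log units; that floor lies within the scatter) and an at least 1.0-fold higher number from compound 2 to compound 3 (0.04 log units; that floor lies within the scatter) carry floors that lie within the scatter, so no ordering of the three compounds can be claimed from these numbers.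

Compound 4 `Cc1c[nH]c(C(c2ccc(-c3ccc4cccc(F)c4c3)[nH]c2=O)C(C)C)n1` has not yet been measured. It differs from compound 2 in that (4-methyl-1H-imidazol-2-yl in place of (isopropylcarbamoyl)methyl on a saturated chain carbon bound to an aromatic carbon and a saturated chain carbon). The entering group resembles the 1H-imidazol-2-yl of compound 1, which sat at the limit. Compound 4 is therefore expected to give about 0.06 h in this assay, within a range of 0.03 h to 0.12 h, and most probably to be reported only as a limit. That estimate means a step that the limit leaves unreadable from compound 2 to compound 4, which is expected to stay within the scatter.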

Compound 4, half-life: < 0.0667 h
Compound 4: only a limit was reported; the forecaster's own chance of this, stated with the estimate: 65%; the middle value does not contradict the limit.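

In this assay, compound 4 is reported only as a limit, which places the 4-methyl-1H-imidazol-2-yl group at the same limit as the 1H-imidazol-2-yl group of compound 1 and the (isopropylcarbamoyl)methyl group of compound 2: the limit of < 0.0667 h in this assay, at which 3 of the 4 values shown sit. The steps from compound 1 and from compound 2 to compound 4 cannot be read, and methyl in place of hydrogen on an aromatic carbon therefore shows no readable effect here. Among the compounds shown here, the only step with a floor, an at least 1.0-fold lower number from compound 3 to compound 4 (0.04 log units; that floor lies within the scatter), does not set compound 3 apart from compound 4.

The compounds shown leave open whether any group on this saturated chain carbon can give a half-life clearly beyond the limit. As far as these compounds go, whether an amine or a carboxylic acid in this place would give a readable value also remains open.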